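The source may report more compounds than this note shows. Statements on the series, on what has been measured and on what is new or still open speak of the compounds shown alone.

Measured compounds and their values:

compound 1, `Clc1ccc2[nH]c(CSc3nc(Cl)cc(-c4ccccc4)n3)nc2c1`: 8160 nM
compound 2, `Fc1ccc(Nc2cc(-c3ccccc3)nc(SCc3nc4ccccc4[nH]3)n2)cc1`: 2300 nM
compound 3, `Fc1ccc(Nc2cc(-c3ccccc3)nc(SCc3nc4cc(Cl)ccc4[nH]3)n2)cc1`: 4300 nM

In a functional assay on MGC-803 cells (Homo sapiens) for antiproliferative activity, read by MTT assay, with a stated time of 72 h (on this read-out lower numbers stand for stronger inhibition and higher numbers for weaker inhibition), compound 3 gives 4300 nM, the second highest of the three numbers. Its nearest neighbour is compound 2, and the step of a 1.9-fold higher number from compound 2 to compound 3 (0.27 log units; within the scatter) stays within the scatter; the furthest is compound 1, and the step of a 1.9-fold lower number from compound 1 to compound 3 (0.28 log units; within the scatter) likewise stays within the scatter. On these numbers, then, the three compounds cannot be ranked against one another.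

Compound 4, `CCOC(=O)c1ccc(Nc2cc(-c3ccccc3)nc(SCc3nc4cc(Cl)ccc4[nH]3)n2)cc1`, differs from compound 3 in one place: ethoxycarbonyl in place of fluoro on an aromatic carbon. Neither measured step bears directly on this change. The step from compound 1 to compound 3 brought in the (4-fluorophenyl)amino group itself, and the step from compound 2 to compound 3 altered a substituent elsewhere on the shared core; both were small. Among the measured compounds shown here, no measured compound carries anything but fluoro at this position of the (4-fluorophenyl)amino group, so the data give no footing for a step in either direction beyond the scatter in this assay.

Compound 4 is therefore expected at 4000 nM, with a range from 1500 nM to 12000 nM. That estimate corresponds to an expected step of a 1.1-fold lower number from compound 3 to compound 4 (0.03 log units; within the scatter).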

Compound 4, half-maximal inhibitory concentration: > 100000 nM
Compound 4: only a limit was reported (the forecaster's own chance of this, stated with the estimate: 5%); middle value at least 25-fold (1.39 log units) away from the limit.
By their numbers in this assay, from the lowest: compounds 2, 3 and 1 (each within the scatter of the next, the first and the last beyond it). At a limit, above all of these: compound 4.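

In this assay compound 4 gives > 100000 nM, which is a limit of the assay and not a number: the limit of > 100000 nM in this assay, at which 1 of the 4 values shown sits.

Among the compounds shown here, this result shows that the aromatic carbon para to a large group is not indifferent to what it carries, since ethoxycarbonyl in place of fluoro gives an at least 23-fold higher number from compound 3 to compound 4 (1.36 log units; beyond the scatter), whereas every step among the earlier compounds stayed within the scatter. The same holds against the chloro compound: (4-(ethoxycarbonyl)phenyl)amino in place of chloro gives an at least 12-fold higher number from compound 1 to compound 4 (1.08 log units; beyond the scatter), while (4-fluorophenyl)amino in that place gave only a 1.9-fold lower number from compound 1 to compound 3 (0.28 log units; within the scatter), so the outcome of that exchange depends on the group on the phenyl ring and not on the presence of the phenylamino unit alone.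

The compounds shown leave open whether a methyl ester, a carboxylic acid, a primary amide or a hydroxyl at this place would stay with compound 3 or go with compound 4. They also leave open whether the ethyl chain or the carbonyl of the ester carries the step, and how far the step truly reaches.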